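This account rests on a few compounds, and the source may have more. Where it says the series, first, only, none or still open, it means among the compounds named here.

Of the compounds shown here, three on a shared core have been measured in an ADME assay on L929 cells (Mus musculus) for cytotoxicity, read by resazurin assay, with a stated time of 48 h (a lower number here means that less compound is tolerated, a higher number that more compound is tolerated), so far. Compound 1 `C#CCn1c2ccc([N+](=O)[O-])cc2c(=O)n1Cc1ccccc1` gives 195000 nM as a true number. Compound 2 `O=C(O)CCn1c2ccc([N+](=O)[O-])cc2c(=O)n1Cc1ccccc1` returns only a limit of the assay, > 256000 nM and no number. Compound 3 `O=C(O)CCCn1c2ccc([N+](=O)[O-])cc2c(=O)n1Cc1ccccc1` also returns only a limit, > 256000 nM and no number. Compound 3 thus stands at the limit of > 256000 nM in this assay, at which 2 of the 3 values shown sit, and has no exact position on the scale.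

The next compound is compound 4 `O=c1c2cc([N+](=O)[O-])ccc2n(CCO)n1Cc1ccccc1`, which has hydroxy in place of carboxymethyl on a saturated chain carbon, two bonds along the chain from an aromatic nitrogen. Going by the values given here, no measured step makes this exact change. The closest evidence is an at least 1.3-fold higher number from compound 1 to compound 2 (0.11 log units; that floor lies within the scatter) and an at least 1.3-fold higher number from compound 1 to compound 3 (0.11 log units; that floor lies within the scatter) and neither of these floors goes beyond the scatter. The chain change gives only a step that the two limits leave unreadable from compound 2 to compound 3 and so offers no size to carry over. Among the compounds with values here, compound 1 at 195000 nM holds the only true number. The whole series sits close to the limit of this assay and compound 4 is expected to stay in that region. The expected result is an at least 1.1-fold lower number from compound 3 to compound 4 (0.06 log units; that floor lies within the scatter) and no step beyond the scatter is foreseen, in either direction. Compound 4 is estimated at 220000 nM in this assay (expected range 110000 nM to 256000 nM).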

Compound 4, concentration lethal to 50% of the cells: > 256000 nM
Compound 4 was reported as a limit; the forecaster's own chance of this, stated with the estimate: 45%; at least 1.1-fold (0.06 log units) between middle value and limit.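

In this assay the earlier compounds reached the limit only with a carboxy group at the end of the chain, but the 2-hydroxyethyl of compound 4 has no such group and reaches it as well, so among these compounds reaching the limit does not depend on the carboxylic acid. Compound 4 returns only a limit of the assay, > 256000 nM, so its steps from the two acids cannot be read. Measured from the ethynyl chain, the change gives an at least 1.3-fold higher number from compound 1 to compound 4 (0.11 log units; that floor lies within the scatter), so the hydroxy chain is not set apart from the ethynyl chain by anything beyond the scatter.

Going by these compounds, how far compound 2, compound 3 and compound 4 lie from one another remains open, as does whether any of them differs from the true number of compound 1 by more than the scatter. Also open is what an amine, an amide or a longer chain ending in hydroxy would return at this position, and whether any of them would give a true number rather than join the compounds at the ceiling, which now stands as: the limit of > 256000 nM in this assay, at which 3 of the 4 values shown sit.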